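Fluoro-to-hydrogen change on the aromatic ring of compound 1

The source may hold more compounds than are shown below. What is called first, only, known or untested is meant among the compounds shown, and "the series" means these compounds.

Compound 1 `Fc1ccc(C2=CC3CNCC(C2)C3)cn1` gives 28 nM in an in vitro assay on SH-SY5Y cells for displacement of a labelled ligand from Neuronal acetylcholine receptor; alpha3/beta4 (Homo sapiens); on this read-out lower numbers stand for stronger inhibition and higher numbers for weaker inhibition. Among the three compounds measured it holds the lowest number: compound 3 `Clc1ccc(C2=CC3CNCC(C2)C3)nn1`, which gives 73 nM, is nearest, and compound 2 `CN1CC2C=C(c3ccc(F)nc3)CC(C2)C1`, which gives 1310 nM, is furthest. For the measured compounds named here, the only step between compounds that differ in a single place, a 47-fold higher number from compound 1 to compound 2 (1.67 log units; beyond the scatter), concerns methyl in place of hydrogen on an amine nitrogen in a ring; it shows how strongly this assay responds to a change at that nitrogen but says nothing about the aromatic ring.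

Compound 4 `C1=C(c2cccnc2)CC2CNCC1C2` is not yet measured. Relative to compound 1 the change is hydrogen in place of fluoro on an aromatic carbon. Going by the values given here, no measured step bears on this change. Compound 3 differs from compound 1 in more than one place, so its higher number cannot be tied to any one change. With nothing to go on for hydrogen in place of fluoro, a step of no more than the usual scatter is expected in this assay, leaning slightly toward a higher number. Compound 4 is therefore expected to give about 45 nM in this assay, with a range from 12 nM to 170 nM. That estimate amounts to a 1.6-fold higher number from compound 1 to compound 4 (0.21 log units; within the scatter).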

Compound 4, inhibition constant: 12 nM
The estimate for compound 4 lay 3.8-fold (0.57 log units) above the measured number, and the stated range covers the measured number.
By their numbers in this assay, from the lowest: compound 4; then compound 1; then compound 3; then compound 2.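

In this assay, hydrogen in place of fluoro on an aromatic carbon next to the ring nitrogen gives a 2.3-fold lower number from compound 1 to compound 4 (0.37 log units; beyond the scatter), so a low number at this position does not depend on the fluoro, and the hydrogen compound sits lower. For the compounds shown here, this is the first single-place step on the aromatic ring, and it is much smaller than a 47-fold higher number from compound 1 to compound 2 (1.67 log units; beyond the scatter), the step at the amine nitrogen, so within these compounds the ring position has so far moved the number less than that nitrogen has. No measurement at hand explains why the number falls when the fluoro leaves.

As far as these compounds go, with only fluoro and hydrogen compared at this carbon, it remains open whether a methoxy or a nitrile there would give a number lower than hydrogen or higher than fluoro. From the compounds shown here alone, it is also open whether the same step would appear with methyl on the amine nitrogen, as in compound 2, and compound 3 still differs from compound 1 in more than one place, so it adds nothing on this position.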